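Methyl on the Core: From One Series to Another

The source may report more compounds than this note shows. Statements on the series, on what has been measured and on what is new or still open speak of the compounds shown alone.

Compound 1 `COCn1c(CC(COCc2ccccc2)COCc2ccccc2)cc(=O)[nH]c1=O` and compound 2 `COCn1c(CC(COCc2ccccc2)COCc2ccccc2)c(C)c(=O)[nH]c1=O` share one core and were both tested in a functional assay on HeLa cells (Homo sapiens) for antiproliferative activity, read by MTT assay, with a stated time of 72 h; on this read-out higher numbers stand for weaker inhibition and lower numbers for stronger inhibition. For compound 1 the read-out is a limit of the assay, > 100000 nM. Compound 2, in this assay, gives 29700 nM. Among the compounds with values here, the single change between them is methyl in place of hydrogen on an aromatic carbon, and the step it made is an at least 3.3-fold lower number from compound 1 to compound 2 (0.52 log units; beyond the scatter). Two of the three values shown sit at a limit, as recorded by the limit of > 100000 nM in this assay, at which 2 of the 3 values shown sit.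

Compound 3 `C[Si](C)(C)CCOCn1c(CC(O)COCc2ccccc2)cc(=O)[nH]c1=O` rests on a different core; how that core differs from the core of compound 1 is not broken down here. In this assay compound 3 reaches only a limit of the assay, > 100000 nM.

Compound 4 `Cc1c(CC(O)COCc2ccccc2)n(COCC[Si](C)(C)C)c(=O)[nH]c1=O` carries the same kind of change as compound 2, (methyl in place of hydrogen on an aromatic carbon). The surroundings differ: in compound 4 the place is meta to a group of 8 heavy atoms, while in compound 2 it is meta to a methoxymethyl group (3 heavy atoms). The step from compound 3 is expected to be an at least 2.5-fold lower number from compound 3 to compound 4 (0.39 log units; beyond the scatter), resting on the earlier step of an at least 3.3-fold lower number from compound 1 to compound 2 (0.52 log units; beyond the scatter), which began at the same limit. Compound 4 is therefore estimated to give 40000 nM, expected to fall between 10000 nM and 150000 nM.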

Compound 4, half-maximal inhibitory concentration: > 100000 nM
Compound 4: a limit, no number; the forecaster's own chance of this, stated with the estimate: 35%; middle value at least 2.5-fold (0.39 log units) away from the limit.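

In this assay compound 4 gives only a limit of the assay, > 100000 nM. Compound 3 also gives only a limit, so no step can be read between compound 3 and compound 4, because neither has a number: the limit of > 100000 nM in this assay, at which 3 of the 4 values shown sit.

As far as these compounds go, whether methyl in place of hydrogen lowers the number on the core of compound 3, as it does from compound 1 to compound 2, stays open.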